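The source may report more compounds than this note shows. Statements on the series, on what has been measured and on what is new or still open speak of the compounds shown alone.

Compound 1 `COc1ncnc2c1ncn2C1O[C@H](CO)[C@H](O[C@@H]2OC(CO)[C@H](OP(=O)(O)O)C(OP(=O)(O)O)[C@@H]2O)[C@@H]1OP(=O)(O)O`: 19 nM
Compound 2 `Nc1ncnc2c1ncn2C1O[C@H](CO)[C@H](O[C@@H]2OC(CO)[C@H](OP(=O)(O)O)C(OP(=O)(O)O)[C@@H]2O)[C@@H]1OP(=O)(O)O`: 14 nM
Compound 3 `CNc1ncnc2c1ncn2C1O[C@H](CO)[C@H](O[C@@H]2OC(CO)[C@H](OP(=O)(O)O)C(OP(=O)(O)O)[C@@H]2O)[C@@H]1OP(=O)(O)O`: 13 nM

In a functional assay (Hepatocyte) with Rattus norvegicus as the target (a lower number here means that less compound is needed, a higher number that more compound is needed for the effect), compound 3 gives the lowest of the three numbers, though its steps to the others, a 1.1-fold lower number from compound 2 to compound 3 (0.03 log units; within the scatter) and a 1.5-fold lower number from compound 1 to compound 3 (0.16 log units; within the scatter), both lie within the scatter, as does a 1.4-fold lower number from compound 1 to compound 2 (0.13 log units; within the scatter). Compound 4 `O=P(O)(O)OC1[C@@H](OP(=O)(O)O)C(CO)O[C@@H](O[C@@H]2[C@H](OP(=O)(O)O)C(n3cnc4c(NC5CCCCC5)ncnc43)O[C@@H]2CO)[C@H]1O` has not been measured. Its change from compound 3 is cyclohexyl in place of methyl on a nitrogen on an aromatic ring. Going by the values given here, no measured step exchanges one such group for a larger one; the only change at this nitrogen, a 1.1-fold lower number from compound 2 to compound 3 (0.03 log units; within the scatter), was small. Compound 4 is therefore expected to stay near compound 3, with no step beyond the scatter, a 1.5-fold higher number from compound 3 to compound 4 (0.19 log units; within the scatter). Compound 4 is estimated at 20 nM, between 7 nM and 60 nM.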

Compound 4, half-maximal effective concentration: 25 nM
Compound 4: the middle estimate sits 1.3-fold (0.10 log units) below what was measured; the range from low to high includes it.
By their numbers in this assay, from the lowest: compounds 3, 2, 1 and 4 (each within the scatter of the next).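

In this assay, the nitrogen on the aromatic ring takes a cyclohexyl ring with no step beyond the scatter, whether it replaces methyl (a 1.9-fold higher number from compound 3 to compound 4 (0.28 log units; within the scatter)) or hydrogen (a 1.8-fold higher number from compound 2 to compound 4 (0.25 log units; within the scatter)). The earlier compounds shown here carried nothing larger than methyl at this nitrogen. Cyclohexylamino in place of methoxy also stays within the scatter (a 1.3-fold higher number from compound 1 to compound 4 (0.12 log units; within the scatter)), and no available data explain this result.

Going by these compounds, whether a phenyl ring, a longer chain or a chain ending in a carboxylic acid or an amine would also stay within the scatter remains open. So does how large a group this nitrogen can carry.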